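The compounds below may be only part of what the source reports. "The series", "measured", "known", "first", "only" and "open" are said of these compounds alone.

In a functional assay on HCT-116 cells (Homo sapiens) for inhibition, read by CCK-8 assay, with a stated time of 48 h (a higher number here means a weaker inhibitor, a lower number a stronger inhibitor), compound 1 `COc1cc(-c2cc3nccc(-c4cc(OC)c(OC)c(OC)c4)n3n2)cc(OC)c1OC` reaches only a limit of the assay, > 10000 nM, and no number is known for it (the limit of > 10000 nM in this assay, at which 1 of the 3 values shown sits). Compound 2 `COc1cc(-c2ccnc3cc(-c4ccc(Cl)cc4)nn23)cc(OC)c1OC` gives 3340 nM in this assay, and compound 3 `COc1cc(-c2ccnc3cc(-c4ccc5cc[nH]c5c4)nn23)cc(OC)c1OC` gives 187 nM. Between those two there is one measured step, an 18-fold lower number from compound 2 to compound 3 (1.25 log units; beyond the scatter), so compound 3 stands with the lowest of the two known numbers, the third value being a limit.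

Compound 4 `COc1cc(-c2ccnc3cc(-c4ccc5cnn(C)c5c4)nn23)cc(OC)c1OC` differs from compound 3 in one place: 1-methyl-1H-indazol-6-yl in place of 1H-indol-6-yl on an aromatic carbon. Among the measured compounds shown here, the only measured step that touches this aromatic carbon, an 18-fold lower number from compound 2 to compound 3 (1.25 log units; beyond the scatter), swapped one aromatic group for a quite different one and was large, which shows that what sits there matters strongly. It does not, however, say what happens when the 1H-indol-6-yl group is kept in shape but its hydrogen-bond donor is removed and two acceptors arrive. A modest weakening is therefore expected, a 2.7-fold higher number from compound 3 to compound 4 (0.43 log units; beyond the scatter), with wide uncertainty. For compound 4 the expected value in this assay is 500 nM, estimated to lie between 150 nM and 2000 nM.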

Compound 4, half-maximal inhibitory concentration: 2440 nM
Compound 4: middle estimate off by 4.9-fold (0.69 log units), on the low side; measured number outside the range, above it.
By their numbers in this assay, from the lowest: compound 3; then compounds 4 and 2 (each within the scatter of the next). At a limit, above all of these: compound 1.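

In this assay, the step of a 13-fold higher number from compound 3 to compound 4 (1.12 log units; beyond the scatter) shows that the low number of compound 3 does not survive this change, even though the group entering on this aromatic carbon also has a five-membered aromatic ring and a six-membered aromatic ring of carbon only. The step of a 1.4-fold lower number from compound 2 to compound 4 (0.14 log units; within the scatter) then leaves the 1-methyl-1H-indazol-6-yl and 4-chlorophenyl groups indistinguishable here, so a second aromatic ring alone does not bring the gain seen with 1H-indol-6-yl. Nothing measured among these compounds explains the loss.

This single change removes a hydrogen-bond donor, adds a ring nitrogen and adds a methyl, and the compounds shown do not separate these parts. The 1H-indazol-6-yl and 1-methyl-1H-indol-6-yl groups on this carbon would each isolate one of them.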